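The compounds below may be only part of what the source reports. "The series", "measured", "known", "first", "only" and "open" are said of these compounds alone.

Values measured so far in a physicochemical assay for lipophilicity (on this read-out higher numbers stand for higher lipophilicity and lower numbers for lower lipophilicity), are:

- compound 1 `CCn1cnc2c(-c3ccc(F)c(-c4cccnc4)c3)cnnc21` gives 2.6
- compound 2 `CC(=O)N1CC(Oc2cc(-c3cnnc4c3ncn4C(C)C)ccc2F)C1` gives 1.6
- compound 3 `CCc1cnn2c(-c3ccc(F)c(-c4ccc(S(=O)(=O)CC)cc4)c3)cnnc12` gives 3.5

Compound 3 at 3.5 stands highest of the three, with compound 1 nearest and compound 2 furthest, both gaps beyond the scatter. Compound 4 `CCS(=O)(=O)c1ccc(-c2cc(-c3cnnc4c(OC)cnn34)ccc2F)cc1` differs from compound 3 in one place: methoxy in place of ethyl on an aromatic carbon with methoxy in place of ethyl on an aromatic carbon of a five-membered aromatic ring with 2 nitrogen. Within the data shown here, no two measured compounds show this swap, so its size is a judgement. A modest fall in this assay is expected, probably just beyond the scatter. The expected change is a number 0.50 log units lower from compound 3 to compound 4 (beyond the scatter) in size. Compound 4 is estimated at 3 with a likely range from 2.6 to 3.4 when it is measured.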

Compound 4, distribution coefficient: 2.8
Estimate against measurement, compound 4: 0.20 log units above; the range from low to high includes it.
By their numbers in this assay, from the lowest: compound 2; then compounds 1 and 4 (each within the scatter of the next); then compound 3.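

Only compounds 3 and 4 differ in one place, and in this assay methoxy in place of ethyl on an aromatic carbon of the five-membered ring gives a step of a number 0.70 log units lower from compound 3 to compound 4 (beyond the scatter) at this position. This swap keeps the heavy-atom count, exchanging a carbon for an oxygen and bringing in a hydrogen-bond acceptor, so the read-out responds to a change of identity rather than of atom count. Nothing measured here explains the step.

On these data alone, an amine, a longer chain or a carboxylic acid at this position remains open. So does the size of the same swap elsewhere on these compounds.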